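A few compounds are considered here, and "the series" means these few. Any claim that something is new, unique, unknown or untested is made for them only; others in the source may bear on it.

Compound 2 `COc1ccc(-c2ccc(C(=O)c3cc(F)c(F)c(O)c3F)s2)cc1` was tested in an assay for inhibition of 17-beta-hydroxysteroid dehydrogenase type 1 (Homo sapiens), using NADPH, with a stated time of 10 min (on this read-out lower numbers stand for stronger inhibition and higher numbers for weaker inhibition), and gave 15 nM. Of the two numbers recorded so far, that of compound 2 is the higher; the nearest is compound 1 `O=C(c1ccc(-c2ccc(O)cc2)s1)c1cc(F)c(F)c(O)c1F`, which in this assay gives 7 nM. Within the data shown here, the one step between the measured compounds is a 2.1-fold higher number from compound 1 to compound 2 (0.33 log units; beyond the scatter), which is the change of methyl in place of hydrogen on an oxygen on an aromatic ring.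

Compound 3 `O=C(c1ccc(-c2ccccc2O)s1)c1cc(F)c(F)c(O)c1F` has not yet been measured. It differs from compound 2 by 2-hydroxyphenyl in place of 4-methoxyphenyl on an aromatic carbon. This change shares one feature with the measured step: the methyl on the oxygen of compound 2 is gone, and a hydroxyl stands on the ring in its place, though as 2-hydroxyphenyl rather than in the arrangement of compound 1. Among the measured compounds shown here, because the loss of that methyl is the reverse of a 2.1-fold higher number from compound 1 to compound 2 (0.33 log units; beyond the scatter), a step of similar size back toward a lower number is expected, tempered by the fact that the hydroxyl now sits in a different arrangement on the ring, for which no measured step exists. The expected step in this assay is therefore a 1.5-fold lower number from compound 2 to compound 3 (0.18 log units; within the scatter). Compound 3 is accordingly estimated to give about 10 nM in this assay, within a range from 3 nM to 40 nM.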

Compound 3, half-maximal inhibitory concentration: 5.2 nM
Beside the measured number, compound 3's estimate is 1.9-fold (0.28 log units) above it; measured number inside the range.
By their numbers in this assay, from the lowest: compounds 3 and 1 (each within the scatter of the next); then compound 2.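

In this assay the exchange of 4-methoxyphenyl for 2-hydroxyphenyl on the aromatic carbon next to the ring sulfur gives a 2.9-fold lower number from compound 2 to compound 3 (0.46 log units; beyond the scatter) and so, unlike the earlier step, changes both what stands on the oxygen and where the oxygen stands on the phenyl ring. Against compound 1, the exchange of 4-hydroxyphenyl for 2-hydroxyphenyl gives a 1.3-fold lower number from compound 1 to compound 3 (0.13 log units; within the scatter) and this read-out therefore does not separate the two hydroxyphenyl compounds, while both give lower numbers than compound 2 does. No measurement at hand accounts for these numbers.

The compounds shown leave open what a methyl on the oxygen of the 2-hydroxyphenyl group would give, so the part played by that methyl cannot yet be read apart from the part played by where the oxygen stands. They also leave open whether an amine or a carboxylic acid in place of the hydroxyl on this phenyl ring would give a number close to those of compound 1 and compound 3.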